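Nitro-aryl ether variant of a trifluoromethylphenyl series

The compounds below may be only part of what the source reports. "The series", "measured", "known", "first", "only" and "open" are said of these compounds alone.

Measured compounds:
compound 1, `CC1(C)CCC(CN2CCN(c3ccc(C(=O)NS(=O)(=O)c4ccc(NCC5CCOCC5)c([N+](=O)[O-])c4)c(Oc4cnc5[nH]ccc5c4)c3)CC2)=C(c2ccc(C(F)(F)F)cc2)C1`: 6.2 nM
compound 2, `CC1(C)CCC(CN2CCN(c3ccc(C(=O)NS(=O)(=O)c4ccc(NCC5CCOCC5)c([N+](=O)[O-])c4)c(Oc4cnc5[nH]ccc5c4)c3)CC2)=C(c2ccccc2C(F)(F)F)C1`: 18 nM

In a functional assay on RS4-11 cells (Homo sapiens) for inhibition, read by CCK-8 assay, with a stated time of 72 h (a higher number here means a weaker inhibitor, a lower number a stronger inhibitor), compound 1 stands at the lowest of the two numbers; the nearest is compound 2, a 2.9-fold higher number from compound 1 to compound 2 (0.46 log units; beyond the scatter). Compound 3, `CC1(C)CCC(CN2CCN(c3ccc(C(=O)NS(=O)(=O)c4ccc(OC5CCOCC5)c([N+](=O)[O-])c4)c(Oc4cnc5[nH]ccc5c4)c3)CC2)=C(c2ccc(C(F)(F)F)cc2)C1`, differs from compound 1 only on the sulfonamide-bearing ring: (oxan-4-yl)oxy in place of ((oxan-4-yl)methyl)amino on an aromatic carbon. For the measured compounds named here, no measured step touches this position, since the single step from compound 1 to compound 2 concerns the trifluoromethylphenyl ring. The change drops a hydrogen-bond donor, so a modest weakening is expected, a 2.9-fold higher number from compound 1 to compound 3 (0.46 log units; beyond the scatter), with wide uncertainty. Compound 3 is estimated at 18 nM, range 5 nM to 70 nM.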

Compound 3, half-maximal inhibitory concentration: 375 nM
Compound 3: the middle estimate sits 21-fold (1.32 log units) below what was measured; measured number outside the range, above it.
By their numbers in this assay, from the lowest: compound 1; then compound 2; then compound 3.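

In this assay the exchange of ((oxan-4-yl)methyl)amino for (oxan-4-yl)oxy gives a 60-fold higher number from compound 1 to compound 3 (1.78 log units; beyond the scatter) and so outweighs the earlier change on the trifluoromethylphenyl ring, a 2.9-fold higher number from compound 1 to compound 2 (0.46 log units; beyond the scatter) in the same read-out. The aromatic carbon ortho to a nitro group is therefore sensitive to this exchange, which removes the hydrogen-bond donor and also changes the linking atoms. No supporting measurement bears on this step.

Going by these compounds, whether the loss of the donor or the change in linker matters more remains open. A (oxan-4-yl)amino group or a (oxan-4-yl)methoxy group on the same carbon would separate the two.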